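Cytotoxicity notes: phenylpropyl series and a cyclopropyl variant

This account rests on a few compounds, and the source may have more. Where it says the series, first, only, none or still open, it means among the compounds named here.

Measured compounds in an ADME assay on MT2 cells (Homo sapiens) for cytotoxicity, read by XTT assay, with a stated time of 4 days; a lower number here means that less compound is tolerated, a higher number that more compound is tolerated:
- compound 1, `Cc1nc2c(c(-c3cc(F)c4c(c3C)CCCO4)c1[C@H](OC(C)(C)C)C(=O)O)CN(CCCc1cccc(F)c1)CC2`: reported as a limit, > 40000 nM
- compound 2, `Cc1nc2c(c(-c3cc(F)c4c(c3C)CCCO4)c1[C@H](OC(C)(C)C)C(=O)O)CN(CCCc1ccc(F)cc1)CC2`: reported as a limit, > 40000 nM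
- compound 3, `Cc1nc2c(c(-c3cc(F)c4c(c3C)CCCO4)c1[C@H](OC(C)(C)C)C(=O)O)CN(CCCc1ccccc1)CC2`: reported as a limit, > 40000 nM

Compound 3 stands at the limit of this assay, and the other two values shown are limits as well. The steps among the measured compounds are therefore not readable: a step that the two limits leave unreadable from compound 1 to compound 2, a step that the two limits leave unreadable from compound 1 to compound 3 and a step that the two limits leave unreadable from compound 2 to compound 3 all end at the same limit. Since (the limit of > 40000 nM in this assay, at which 3 of the 3 values shown sit), no size or direction can be taken from any of them.

Compound 4, `Cc1nc2c(c(-c3cc(F)c4c(c3C)CCCO4)c1[C@H](OC(C)(C)C)C(=O)O)CN(CC1CC1c1ccccc1)CC2`, is the next member. The change from compound 3 is 2-phenylcyclopropyl in place of phenethyl on a saturated chain carbon bound to an amine nitrogen in a ring. Within the data shown here, the steps that bear on it are those from compound 1 and compound 2 to compound 3, both unreadable, and none of the measured compounds carries a three-membered ring.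

With every value shown sitting at the limit and no readable step, the expectation for compound 4 is that this assay again reports a limit, and the step from compound 3 is expected to be a number no higher from compound 3 to compound 4 (the limit leaves the size open). Compound 4 is thus estimated at 40000 nM, within 20000 nM to 80000 nM.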

Compound 4, half-maximal cytotoxic concentration: > 40000 nM
Compound 4: no number, only a limit; the forecaster's own chance of this, stated with the estimate: 85%; the middle value sits exactly at the limit.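

In this assay compound 4 gives > 40000 nM, a limit and not a number. The steps from compound 1, compound 2 and compound 3 to compound 4 therefore cannot be read: the limit of > 40000 nM in this assay, at which 4 of the 4 values shown sit.

The compounds shown leave open what cytotoxic concentration any of them has, and whether 2-phenylcyclopropyl and phenethyl differ at all in this read-out.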